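Methyl in Place of Hydrogen on an Aromatic Oxygen

The source may report more compounds than this note shows. Statements on the series, on what has been measured and on what is new or still open speak of the compounds shown alone.

Three compounds were measured in a functional assay on BMEC cells (Bos taurus) for antiproliferative activity; on this read-out lower numbers stand for stronger inhibition and higher numbers for weaker inhibition:
Compound 1, `COc1cc(/C=C/Cc2cc(O)c3ccsc3c2)cc(OC)c1OC`, gives 38700 nM.
Compound 2, `COc1cc(/C=C/Cc2cc(OC)c3ccsc3c2)cc(OC)c1OC`, gives 53000 nM.
Compound 3, `COc1cc(/C=C\Cc2cc(O)c3ccccc3c2)cc(OC)c1OC`, gives 670 nM.

The change from compound 1 to compound 2 is methyl in place of hydrogen on an oxygen on an aromatic ring. It made a 1.4-fold higher number from compound 1 to compound 2 (0.14 log units; within the scatter). Compound 4, `COc1cc(/C=C\Cc2cc(OC)c3ccccc3c2)cc(OC)c1OC`, is derived from compound 3 by the same change, (methyl in place of hydrogen on an oxygen on an aromatic ring); the place is described in the same words for both pairs. The difference between the core of compound 1 and the core of compound 3 is not broken down here; compound 3 has the lowest number of the three, and its steps to compound 1 and compound 2 lie beyond the scatter. The step from compound 3 to compound 4 is expected to be small, as a 1.3-fold higher number from compound 3 to compound 4 (0.13 log units; within the scatter), because the same change gave a 1.4-fold higher number from compound 1 to compound 2 (0.14 log units; within the scatter). Compound 4 is therefore estimated at 900 nM, between 300 nM and 3000 nM.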

Compound 4, half-maximal inhibitory concentration: 10000 nM
Compound 4: the middle estimate sits 11-fold (1.05 log units) below what was measured; measured number above the stated range.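

In this assay, methyl in place of hydrogen on an oxygen on an aromatic ring gave a 15-fold higher number from compound 3 to compound 4 (1.17 log units; beyond the scatter), so the size of this step did not carry over from one core to the other: the same change on two cores in this assay, a 1.4-fold higher number (0.14 log units; within the scatter) from compound 1 to compound 2 and a 15-fold higher number (1.17 log units; beyond the scatter) from compound 3 to compound 4, 11-fold (1.04 log units) apart, beyond the scatter of two such steps

For the compounds shown here, only the step on the core of compound 3 lies beyond the scatter, so hydroxy to methoxy cannot be read as a change of fixed size. These two pairs do not show which feature of the two cores accounts for the gap, nor how the change would behave on a third core.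

From the compounds shown here alone, it remains open whether an ethyl or acetyl group on that oxygen would behave as methyl does on the core of compound 3. Going by these compounds, it also remains open how an amine in place of the hydroxy would behave there.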